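Branching the Ketone Chain: Compound 2 to Compound 4

The compounds below may be only part of what the source reports. "The series", "measured", "known", "first", "only" and "open" are said of these compounds alone.

Three compounds built around a shared core of two aryl ethers joined by a four-carbon linker have been tested in an assay on HEK293 cells for positive allosteric modulation of metabotropic glutamate receptor 2 (Rattus norvegicus), read by thallium flux, with a stated time of 2.5 min; on this read-out lower numbers stand for an effect already at smaller amounts and higher numbers for an effect only at larger amounts of compound. Compound 2 `CCCC(=O)c1ccc(OCCCCOc2ccc(F)c(C(=O)O)c2)c(C)c1O` gives 74 nM, the lowest number among the three; compound 1 `COc1ccc(C(=O)O)cc1OCCCCOc1ccc(C(=O)CC(C)C)c(O)c1C` gives 155 nM and compound 3 `Cc1cc(C(=O)O)ccc1OCCCCOc1ccc(C(=O)CC2CCCC2)c(O)c1C` gives 608 nM, and both of these gaps lie beyond the usual scatter, so compound 2 stands as the most potent of the set. Compound 4 `Cc1c(OCCCCOc2ccc(F)c(C(=O)O)c2)ccc(C(=O)C(C)C)c1O` is yet to be measured in this assay. It differs from compound 2 in one place (isopropyl in place of propyl on a carbonyl carbon), the two sharing the same atoms joined differently; in other words, it carries isopropyl in place of propyl on a carbonyl carbon whose other neighbour is an aromatic carbon. Within the data shown here, no measured pair isolates this particular change, so there is no step to lean on. The author expects a small step from compound 2 to compound 4 of a 1.6-fold higher number from compound 2 to compound 4 (0.21 log units; within the scatter), likely within the scatter or a modest shift towards higher numbers. Compound 4 is estimated at 120 nM, with a range from 40 nM to 360 nM.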

Compound 4, half-maximal effective concentration: 171 nM
The estimate for compound 4 lay 1.4-fold (0.15 log units) below the measured number; low and high end bracket the measured number.
By their numbers in this assay, from the lowest: compound 2; then compounds 1 and 4 (each within the scatter of the next); then compound 3.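

In this assay, among these compounds, the change to isopropyl from propyl on a carbonyl carbon gives a 2.3-fold higher number from compound 2 to compound 4 (0.36 log units; beyond the scatter), the first step in this set that isolates a single place. It shows that this position responds to how the chain is joined, even though the heavy-atom count of the group stays the same, and the modest step lies beyond the scatter. Nothing at hand accounts for this step.

From the compounds shown here alone, it remains open whether an ethyl group, a butyl chain or a cyclopropyl ring on this carbonyl carbon would give a number closer to that of propyl or of isopropyl. Also open, going by these compounds, is whether the same change would give a step of similar size if a methoxy group replaced the fluorine on the acid-bearing ring.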